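The compounds below may be only part of what the source reports. "The series", "measured", "known", "first", "only" and "open" are said of these compounds alone.

Measured so far in an ADME assay on cells (Fibroblast, Homo sapiens) for inhibition, read by MTT assay, with a stated time of 24 h; on this read-out lower numbers stand for stronger inhibition and higher numbers for weaker inhibition:
- compound 1 `Nc1ccc(C(=O)N/N=C/c2ccc3c(c2)no[n+]3[O-])cc1`: > 200000 nM
- compound 2 `CCCOc1ccc(C(=O)N/N=C/c2ccc3c(c2)no[n+]3[O-])cc1`: > 200000 nM

Both entries are assay limits, not numbers. On these data alone, compound 2 stands at a limit, > 200000 nM, so its true position is unknown. Across the series so far, the record shows (the limit of > 200000 nM in this assay, at which 2 of the 2 values shown sit).

Next is compound 3 `O=C(N/N=C/c1ccc2c(c1)no[n+]2[O-])c1ccc(Br)cc1`, with the change bromo in place of propoxy on an aromatic carbon, para to a large group. For the measured compounds named here, the only measured step is a step that the two limits leave unreadable from compound 1 to compound 2. Going by the values given here, it offers no size to carry over, and no measured step covers a bromo group.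

With no number in the series, no step beyond the usual scatter is expected in this assay, and the estimate stays anchored on the limit of compound 2 at > 200000 nM. The expected change is a number no higher from compound 2 to compound 3 (the limit leaves the size open). For compound 3 the estimated value is 200000 nM. The expected range for compound 3 runs from 80000 nM to 400000 nM.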

Compound 3, half-maximal inhibitory concentration: > 200000 nM
Compound 3 was reported as a limit; the forecaster's own chance of this, stated with the estimate: 80%; the middle value lies on the limit itself.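

For the compounds shown here, compound 3 is reported as a limit (> 200000 nM) in this assay, not as a number, so no step among compound 1, compound 2 and compound 3 can be read. The compounds shown leave open where each truly stands and whether amino, propoxy or bromo makes any difference to this read-out.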